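A few compounds are considered here, and "the series" means these few. Any claim that something is new, unique, unknown or untested is made for them only; others in the source may bear on it.

Measured so far in a functional assay on MCF7 cells (Homo sapiens) for cytotoxicity, read by MTT assay, with a stated time of 72 h; on this read-out higher numbers stand for weaker inhibition and lower numbers for stronger inhibition:
compound 1, `Cc1cc(=O)n(-c2ccc(F)cc2)nc1C(=O)Nc1ccc(Oc2ncnc3sccc23)cc1`, 21000 nM
compound 2, `Cc1cc(=O)n(-c2cccc(F)c2)nc1C(=O)Nc1ccc(Oc2ncnc3sccc23)c(F)c1`, 17300 nM
compound 3, `Cc1ccc(-n2nc(C(=O)Nc3ccc(Oc4ncnc5sccc45)c(F)c3)c(C)cc2=O)cc1`, > 40000 nM

Compound 3 stands at the weak end of what has been measured. Its value in this assay is a limit of the assay and not a number, so only a floor is known; it sits at the limit of > 40000 nM in this assay, at which 1 of the 3 values shown sits. Compound 1 and compound 2 give numbers that lie within the scatter of each other.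

Compound 4, `Cc1cc(=O)n(-c2ccc(F)cc2)nc1C(=O)Nc1ccc(Oc2ncnc3sccc23)c(F)c1`, is not yet measured. It differs from compound 3 by fluoro in place of methyl on an aromatic carbon, so the 4-methylphenyl on the aromatic nitrogen becomes a 4-fluorophenyl. For the measured compounds named here, one measured step bears on this ring: an at least 2.3-fold higher number from compound 2 to compound 3 (0.36 log units; beyond the scatter). That change in the other direction, away from 4-methylphenyl toward a fluorophenyl, went with a lower number. Compound 1, which also carries a 4-fluorophenyl on the aromatic nitrogen, gives 21000 nM. A fall beyond the scatter is therefore expected in this assay, and the expected step is an at least 2.0-fold lower number from compound 3 to compound 4 (0.30 log units; that floor lies within the scatter). Compound 4 is estimated at 20000 nM, within a range from 8000 nM to 45000 nM.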

Compound 4, half-maximal inhibitory concentration: 12300 nM
Beside the measured number, compound 4's estimate is 1.6-fold (0.21 log units) above it, within the range that was stated.
By their numbers in this assay, from the lowest: compounds 4, 2 and 1 (each within the scatter of the next). At a limit, above all of these: compound 3.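

In this assay, fluoro in place of methyl gives an at least 3.2-fold lower number from compound 3 to compound 4 (0.51 log units; beyond the scatter); the earlier step on this ring changed the substituent's place as well as its kind, whereas this one holds the place fixed and ties the difference to methyl against fluoro. On these data alone, compound 3 stands at a limit of the assay and not at a number, so the full size of this step remains unknown: the limit of > 40000 nM in this assay, at which 1 of the 4 values shown sits. The other two steps, a 1.4-fold lower number from compound 2 to compound 4 (0.15 log units; within the scatter) and a 1.7-fold lower number from compound 1 to compound 4 (0.23 log units; within the scatter), both lie within the scatter, so neither moving the fluoro on the phenyl ring nor adding the further fluoro separates these compounds.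

Only methyl and fluoro are compared at this place. As far as these compounds go, whether a 4-chlorophenyl, a 4-methoxyphenyl or an unsubstituted phenyl on the aromatic nitrogen would fall with compound 4 or with compound 3 remains open.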